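A few compounds are considered here, and "the series" means these few. Any claim that something is new, unique, unknown or untested is made for them only; others in the source may bear on it.

In an in vitro ADME assay on microsomes (Rattus norvegicus) for metabolic stability (a higher number here means that the compound lasts longer, a lower number that the compound disappears faster), three compounds have been measured. Compound 1 (`CCOc1nc(-c2ccc(Cl)cc2Cl)c(CC)nc1NC(CC)CC`) gives 1.23 h, compound 2 (`CCc1nc(-c2ccc(Cl)cc2Cl)c(CC)nc1SC(C)CC`) gives 0.0683 h, and compound 3 (`CCc1nc(NC(CC)CC)c(F)nc1-c1ccc(Cl)cc1Cl`) gives 0.35 h. That makes compound 3 the second highest of the three, under compound 1 and over compound 2.

Compound 4 (`CCc1nc(-c2ccc(Cl)cc2Cl)c(CC)nc1NC(CC)CC`) has ethyl in place of fluoro on an aromatic carbon of compound 3 (ethyl in place of fluoro on an aromatic carbon). Within the data shown here, the one measured step at this carbon is a 3.5-fold lower number from compound 1 to compound 3 (0.55 log units; beyond the scatter), with fluoro in place of ethoxy. This modest step shows that a change here can move the half-life, but it does not test an ethyl group. Among the measured compounds shown here, compound 2 does hold ethyl on this carbon and gives 0.0683 h, yet it has a sulfur-linked chain instead of the (pentan-3-yl)amino group, so no measured pair isolates the ethyl. With the evidence pulling in opposite directions, no shift beyond the scatter is expected, although a modest move either way remains possible. The expected change is a 1.1-fold higher number from compound 3 to compound 4 (0.06 log units; within the scatter). In this assay, the estimate for compound 4 is 0.4 h, with an expected range from 0.14 h to 1 h.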

Compound 4, half-life: 0.07 h
Beside the measured number, compound 4's estimate is 5.7-fold (0.76 log units) above it; the whole stated range lies above it.
By their numbers in this assay, from the lowest: compounds 2 and 4 (each within the scatter of the next); then compound 3; then compound 1.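

In this assay, ethyl on this aromatic carbon, ortho to a (pentan-3-yl)amino group, now has its own measured steps: a 5.0-fold lower number from compound 3 to compound 4 (0.70 log units; beyond the scatter), and against ethoxy the step is larger, an 18-fold lower number from compound 1 to compound 4 (1.24 log units; beyond the scatter). With the (pentan-3-yl)amino group held constant, ethoxy therefore gives the longest half-life, fluoro a shorter one and ethyl the shortest, all three separated by more than the scatter. Compound 4 also supplies the missing comparison for compound 2, a 1.0-fold higher number from compound 2 to compound 4 (0.01 log units; within the scatter), so with ethyl on this carbon, swapping (sec-butyl)sulfanyl for (pentan-3-yl)amino leaves no difference that can be read, and no measured evidence is available to explain any of these steps.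

The compounds shown leave open whether a methoxy group or a longer alkoxy chain on this carbon would match ethoxy, and whether a methyl group would fall with ethyl or nearer to fluoro. As far as these compounds go, it also remains open whether the same order of ethoxy, fluoro and ethyl would hold with (sec-butyl)sulfanyl, or with a cyclic amine, in place of the (pentan-3-yl)amino group.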